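Adding a ring methyl to compound 2

A few compounds are considered here, and "the series" means these few. Any claim that something is new, unique, unknown or untested is made for them only; others in the source may bear on it.

In an ADME assay on microsomes from liver (Mus musculus) for metabolic stability, read by LC-MS, with a stated time of 30 min, tested at 1 uM (on this read-out higher numbers stand for a more stable compound and lower numbers for a less stable compound), compound 2 `CC(=O)N1CCN(C(=O)[C@@H]2CC[C@@H](C)N2C(=O)C2=C(C(C)C)N3C(=N[C@@](C)(c4ccc(Cl)cc4)[C@H]3c3ccc(Cl)cc3)S2)CC1` gives 13%, the lowest of the three numbers, while compound 1 `CC(C)C1=C(C(=O)N2[C@H](C)CC[C@H]2C(=O)N2CCN(C)CC2)SC2=N[C@@](C)(c3ccc(Cl)cc3)[C@@H](c3ccc(Cl)cc3)N21` gives 25% and compound 3 `CC[C@@H]1CC[C@@H](C(=O)N2CCN(C(C)=O)CC2)N1C(=O)C1=C(C(C)C)N2C(=N[C@@](C)(c3ccc(Cl)cc3)[C@H]2c2ccc(Cl)cc2)S1` gives 38%. Compound 4 `CC(=O)N1CCN(C(=O)[C@@H]2CC[C@@H](C)N2C(=O)C2=C(C(C)C)N3C(=N[C@@](C)(c4ccc(Cl)cc4)[C@H]3c3ccc(Cl)cc3)S2)C[C@H]1C` differs from compound 2 in one place: methyl in place of hydrogen on a saturated ring carbon. The only measured methyl addition, on a saturated chain carbon bound to a saturated ring carbon, is a number 25 percentage points higher from compound 2 to compound 3 (beyond the scatter). The step with acetyl in place of methyl on an amine nitrogen in a ring is a number 12 percentage points lower from compound 1 to compound 2 (beyond the scatter). Neither step puts a methyl on this ring carbon, so only the direction of the first is carried over, at reduced size. The expected change is a number 7 percentage points higher from compound 2 to compound 4 (within the scatter). For compound 4 the estimated value is 20%, with an expected range of 8% to 38%.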

Compound 4, percent of the compound remaining: 55%
Beside the measured number, compound 4's estimate is 35 percentage points below it; the measured number lies above the stated range.
By their numbers in this assay, from the lowest: compound 2; then compound 1; then compound 3; then compound 4.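

In this assay, a methyl on a saturated ring carbon of the six-membered non-aromatic ring with 2 nitrogen gives a number 42 percentage points higher from compound 2 to compound 4 (beyond the scatter), so this ring carbon is a sensitive place for a small change. With this methyl the acetyl-bearing ring also reverses the earlier loss of a number 12 percentage points lower from compound 1 to compound 2 (beyond the scatter), giving a number 30 percentage points higher from compound 1 to compound 4 (beyond the scatter). The data shown offer no explanation for this gain.

Open, from the compounds shown here alone, is whether a hydroxyl or a fluorine on this ring carbon would do the same. Also open, going by these compounds, is whether this methyl adds to a number 25 percentage points higher from compound 2 to compound 3 (beyond the scatter) when both changes are combined.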